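Swapping 2-methoxyphenyl for 4-bromophenyl on compound 1

The source may report more compounds than this note shows. Statements on the series, on what has been measured and on what is new or still open speak of the compounds shown alone.

Compound 1 `COc1ccccc1/C=C/C(=O)OC/C=C/c1cc(OC)c(OC)cc1OC` gives 780 umol/kg
Compound 2 `COc1cc(OC)c(OC)cc1/C=C/COC(=O)/C=C/c1ccc(OC)c(OC)c1` gives > 723 umol/kg
Compound 3 `COc1cc(OC)c(OC)cc1/C=C/COC(=O)/C=C/c1cc(OC)c(OC)c(OC)c1OC` gives > 421 umol/kg

For the measured compounds named here, in a functional assay on the whole organism (strain Kunming) with Mus musculus as the target, with a stated time of 0.5 h (a higher number here means that more compound is needed for the effect, a lower number that less compound is needed), compound 1 gives 780 umol/kg as the only true number among the three. For compound 2, > 723 umol/kg is a limit and not a number. For compound 3, > 421 umol/kg is likewise a limit and not a number.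

Compound 4 `COc1cc(OC)c(OC)cc1/C=C/COC(=O)/C=C/c1ccc(Br)cc1` differs from compound 1 on a double-bonded chain carbon bound to a double-bonded chain carbon, where 4-bromophenyl stands in place of 2-methoxyphenyl: 4-bromophenyl in place of 2-methoxyphenyl on a double-bonded chain carbon bound to a double-bonded chain carbon and the rest stays shared.

Going by the values given here, the one measured step at this place, with 3,4-dimethoxyphenyl entering, is a step that the limit leaves unreadable from compound 1 to compound 2 and so offers no size to carry over. Without a readable step, no change beyond the scatter can be expected in either direction in this assay and compound 4 may also return only a limit. The expected step is a 1.0-fold lower number from compound 1 to compound 4 (0.02 log units; within the scatter) with neither direction favoured. Compound 4 is expected near 750 umol/kg within an estimated range from 350 umol/kg to 1600 umol/kg in this assay.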

Compound 4, dose for half-maximal effect: > 692 umol/kg
Compound 4 ended at the assay's limit (the forecaster's own chance of this, stated with the estimate: 55%); the middle value is on the limit's open side.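

For compound 4, > 692 umol/kg is a limit and not a number, so the steps from compound 1 to compound 4 and from compound 2 to compound 4 cannot be read. The compounds shown leave open whether swapping the group at this place changes the dose needed in this assay at all.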